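This account rests on a few compounds, and the source may have more. Where it says the series, first, only, none or still open, it means among the compounds named here.

Compound 1: `O=C(COCc1ccccc1)N1CCN(c2ccc(Cl)cc2Cl)CC1` — 1000 nM
Compound 2: `O=C(COCc1ccccc1)N1CCN(c2ccc(F)cc2Cl)CC1` — 270 nM

Both compounds share one core and differ only in the aromatic ring on the ring nitrogen. In a functional assay on HEK293 cells for positive allosteric modulation of metabotropic glutamate receptor 5 (Homo sapiens), read by FLIPR and calcium flux (on this read-out lower numbers stand for an effect already at smaller amounts and higher numbers for an effect only at larger amounts of compound), compound 1 gives 1000 nM, while compound 2 gives 270 nM, the lowest of the two numbers; the step of a 3.7-fold lower number from compound 1 to compound 2 (0.57 log units; beyond the scatter) is the only measured one. Compound 3 is `O=C(COCc1ccccc1)N1CCN(c2ccncc2)CC1` and has not yet been measured. Its change is pyridin-4-yl in place of 2-chloro-4-fluorophenyl on an amine nitrogen in a ring. Among the measured compounds shown here, the one measured step swapped a single halogen for another on the same ring and so does not speak to this change, which removes both halogens and exchanges the ring itself for one carrying a nitrogen. Both measured compounds hold a halogen-bearing ring of carbon only, and their values lie close together, so nothing here shows how this assay responds to a ring without halogens. The expectation for compound 3 is a higher number, with wide uncertainty and a real chance that only a limit is reported. Compound 3 is estimated at 3000 nM (range 500 nM to 30000 nM), an expected step of an 11-fold higher number from compound 2 to compound 3 (1.05 log units; beyond the scatter).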

Compound 3, half-maximal effective concentration: > 25000 nM
Compound 3 was reported as a limit (the forecaster's own chance of this, stated with the estimate: 35%); middle value at least 8.3-fold (0.92 log units) from the limit.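

In this assay, compound 3 stands at a limit of the assay, not at a measured number: the limit of > 25000 nM in this assay, at which 1 of the 3 values shown sits. Even read as a limit, the change is large: pyridin-4-yl in place of 2-chloro-4-fluorophenyl gives an at least 92-fold higher number from compound 2 to compound 3 (1.96 log units; beyond the scatter), and pyridin-4-yl in place of 2,4-dichlorophenyl gives an at least 25-fold higher number from compound 1 to compound 3 (1.39 log units; beyond the scatter). The earlier swap of one halogen for another gave only a 3.7-fold lower number from compound 1 to compound 2 (0.57 log units; beyond the scatter), so this result adds something new: the aromatic ring on this amine nitrogen can shift the read-out much further than that swap alone suggested.

The compounds shown leave open which part of the change matters, as the halogens leave and a ring nitrogen enters in the same step, and the two effects cannot be told apart here. A plain phenyl ring with no halogen would test the loss of the halogens alone, while a chloro-substituted pyridine ring would test the ring nitrogen with a halogen still in place.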